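A few compounds are considered here, and "the series" means these few. Any claim that something is new, unique, unknown or untested is made for them only; others in the source may bear on it.

Measured so far in a functional assay on MCF7 cells (Homo sapiens) for antiproliferative activity, read by MTT assay, with a stated time of 72 h; on this read-out higher numbers stand for weaker inhibition and lower numbers for stronger inhibition:
compound 1 `O=c1cc(CSC(=S)N2CCCC2)oc2ccccc12` — 35800 nM
compound 2 `O=c1cc(CSC(=S)N2CCCC2)oc2cc(Cl)ccc12` — > 25000 nM, which is a limit of the assay, not a number
compound 3 `O=c1c(Cl)c(CSC(=S)N2CCCC2)oc2ccccc12` — 2300 nM

Compound 1 holds the highest of the two numbers in this assay. Its nearest neighbour is compound 3, reached by chloro in place of hydrogen on an aromatic carbon, a step of a 16-fold lower number from compound 1 to compound 3 (1.19 log units; beyond the scatter). The other chloro-for-hydrogen change, also on an aromatic carbon, gives a step that the limit leaves unreadable from compound 1 to compound 2 because compound 2 sits at the limit of > 25000 nM in this assay, at which 1 of the 3 values shown sits.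

Compound 4 `O=c1cc(CSC(=S)N2CCOCC2)oc2ccccc12` is not yet measured. Its change from compound 1 is morpholin-4-yl in place of pyrrolidin-1-yl on a thiocarbonyl carbon. Both measured steps alter an aromatic carbon of the shared core and leave the thiocarbonyl-bound ring untouched, so neither bears on this change; the two chloro steps are the only ones known, and one of them is unreadable. Going by the values given here, with no step touching the thiocarbonyl-bound ring, the expectation is that compound 4 stays near compound 1, with no step beyond the scatter, and the estimated step is a 1.1-fold higher number from compound 1 to compound 4 (0.05 log units; within the scatter). Compound 4 is therefore estimated at 40000 nM in this assay, within a range of 15000 nM to 110000 nM.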

Compound 4, half-maximal inhibitory concentration: 21000 nM
For compound 4 the middle estimate is 1.9-fold (0.28 log units) above the measured one; the measured number falls inside the stated range.
By their numbers in this assay, from the lowest: compound 3; then compounds 4 and 1 (each within the scatter of the next).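

In this assay, morpholin-4-yl in place of pyrrolidin-1-yl on a thiocarbonyl carbon gives a 1.7-fold lower number from compound 1 to compound 4 (0.23 log units; within the scatter), the only step shown at this position, so a six-membered ring with 2 hetero atoms and a hydrogen-bond acceptor is accepted here without a step beyond the scatter. This differs from the chloro step on an aromatic carbon of the shared core, which gives a 16-fold lower number from compound 1 to compound 3 (1.19 log units; beyond the scatter), although a single swap at the thiocarbonyl carbon cannot separate ring size from the added oxygen. No measured property in the data bears on this result.

For compound 2, > 25000 nM is a limit of the assay and not a number, and its step cannot be read. Going by these compounds, it remains open whether piperidin-1-yl, with a six-membered ring and no oxygen, or an open-chain diethylamino group would stay as close to compound 1 at this position, and whether a piperazin-1-yl ring carrying a second amine nitrogen would do the same.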